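Ethyl for methyl in two related series

This account rests on a few compounds, and the source may have more. Where it says the series, first, only, none or still open, it means among the compounds named here.

Compound 1 `C=C(c1ccc2c(c1)C=CC(C)(C)O2)c1ccc(OC)cc1NC(=O)CNC` gives 410 nM in a functional assay on HeLa cells (Homo sapiens) for antiproliferative activity, read by MTT assay, with a stated time of 48 h; on this read-out higher numbers stand for weaker inhibition and lower numbers for stronger inhibition. Going by the values given here, compound 2 `C=C(c1ccc2c(c1)C=CC(C)(C)O2)c1ccc(OC)cc1NC(=O)CNCC` carries the change methyl in place of hydrogen on a saturated chain carbon bound to an amine nitrogen and gives 1580 nM in this assay; the step of a 3.9-fold higher number from compound 1 to compound 2 (0.59 log units; beyond the scatter) is the only measured instance of this change. Compound 3 `C=C(c1cc(OC)c(OC)c(OC)c1)c1ccc(OC)c(O)c1NC(=O)COC` rests on a different core; the difference between the two cores is not broken down here. In this assay compound 3 gives 330 nM, which sits close to the number of compound 1.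

Compound 4 `C=C(c1cc(OC)c(OC)c(OC)c1)c1ccc(OC)c(O)c1NC(=O)COCC` is made from compound 3 by the change (methyl in place of hydrogen on a saturated chain carbon bound to an oxygen on a saturated carbon). This is the same kind of change as in the step from compound 1 to compound 2, but the place differs: there the carbon was bound to an amine nitrogen, here it is bound to an oxygen on a saturated carbon. Among the compounds with values here, because the single precedent, a 3.9-fold higher number from compound 1 to compound 2 (0.59 log units; beyond the scatter), points to a loss, a weaker number is expected for compound 4, and the step of a 2.1-fold higher number from compound 3 to compound 4 (0.33 log units; beyond the scatter) is estimated to be somewhat smaller given the different surroundings. Compound 4 is therefore expected to give about 700 nM in this assay, within 300 nM to 1700 nM.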

Compound 4, half-maximal inhibitory concentration: 690 nM
The estimate for compound 4 lay 1.0-fold (0.01 log units) above the measured number, and the stated range covers the measured number.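

In this assay the change from methoxy to ethoxy brings a 2.1-fold higher number from compound 3 to compound 4 (0.32 log units; beyond the scatter), which runs in the same direction as the earlier step, a 3.9-fold higher number from compound 1 to compound 2 (0.59 log units; beyond the scatter). Set side by side, the two steps cannot be told apart in size: the same change on two cores in this assay, a 3.9-fold higher number (0.59 log units; beyond the scatter) from compound 1 to compound 2 and a 2.1-fold higher number (0.32 log units; beyond the scatter) from compound 3 to compound 4, 1.8-fold (0.27 log units) apart, within the scatter of two such steps. Going by these compounds alone, this shows that the loss seen on the core of compound 1 also appears on the core of compound 3, but it rests on only two steps, and the two differ in both core and place, with the carbon bound to an amine nitrogen in one and to an oxygen on a saturated carbon in the other, so the effect of the core cannot be separated from that of the place.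

The compounds shown leave open whether a longer chain, such as propyl, would continue in the same direction on either core. They also leave open whether an amine in place of the ether oxygen on the core of compound 3 would give a step like the one on the core of compound 1, which would separate core from place.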